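The source may report more compounds than this note shows. Statements on the series, on what has been measured and on what is new or still open speak of the compounds shown alone.

Compound 1 `O=C(Nc1cccc(-c2oc3cc(-c4ccc(F)cc4)ccc3c(=O)c2O)c1)c1ccc(F)cc1F` carries a 2,4-difluorophenyl group on the carbonyl carbon of the amide, and in a functional assay on MDA-MB-231 cells (Homo sapiens) for antiproliferative activity, read by CCK-8 assay, with a stated time of 72 h (on this read-out higher numbers stand for weaker inhibition and lower numbers for stronger inhibition), compound 1 gives 11200 nM. Compound 2 `COc1cccc(C(=O)Nc2cccc(-c3oc4cc(-c5ccc(F)cc5)ccc4c(=O)c3O)c2)c1` exchanges that group for a 3-methoxyphenyl, and in this assay compound 2 gives 9160 nM. Going by the values given here, the step of a 1.2-fold lower number from compound 1 to compound 2 (0.09 log units; within the scatter) is the only measured comparison here, and it shows that exchanging the aromatic group on the carbonyl carbon left the read-out within the scatter, so compound 2 and compound 1 stand side by side with nothing to separate them.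

Compound 3 `CCc1ccc(C(=O)Nc2cccc(-c3oc4cc(-c5ccc(F)cc5)ccc4c(=O)c3O)c2)cc1` continues this series of amide variations: the change is 4-ethylphenyl in place of 3-methoxyphenyl on a carbonyl carbon. Among the compounds with values here, the one measured step that bears on it, a 1.2-fold lower number from compound 1 to compound 2 (0.09 log units; within the scatter), was itself within the scatter, and no other measured pair speaks to a change at this position. Compound 3 is therefore expected to show a step of a 1.0-fold higher number from compound 2 to compound 3 (0.02 log units; within the scatter), with no shift beyond the scatter in this assay. On that basis compound 3 is estimated at 9500 nM, with a range from 4000 nM to 22000 nM.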

Compound 3, half-maximal inhibitory concentration: 9070 nM
Beside the measured number, compound 3's estimate is 1.0-fold (0.02 log units) above it; low and high end bracket the measured number.
By their numbers in this assay, from the lowest: compounds 3, 2 and 1 (each within the scatter of the next).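

In this assay, placing 4-ethylphenyl on the carbonyl carbon in place of 3-methoxyphenyl gives a 1.0-fold lower number from compound 2 to compound 3 (0.00 log units; within the scatter) and so takes away the hydrogen-bond acceptor of the group that leaves, with a group of carbon only entering and the read-out remaining within the scatter. Measured against the 2,4-difluorophenyl group, the same 4-ethylphenyl gives a 1.2-fold lower number from compound 1 to compound 3 (0.09 log units; within the scatter), so a fluorine-bearing, an oxygen-bearing and a carbon-only phenyl group on this carbonyl carbon now stand together, with nothing to separate the three compounds in this read-out. Nothing at hand accounts for this lack of separation.

From the compounds shown here alone, the three compounds show only substituted phenyl groups at this place, so it remains open whether a group of another kind, such as a cyclohexyl ring, a pyridine ring, a phenyl ring carrying a piperazine or a carboxylic acid, or a longer alkyl chain, would move the number beyond the scatter. Also open, going by these compounds, is whether the amide linkage itself, or the 4-fluorophenyl group on the shared core, has any bearing on the read-out, as both stay the same throughout these compounds.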